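Butyl replacing the dimethylisoxazole on the sulfonyl aryl

This account rests on a few compounds, and the source may have more. Where it says the series, first, only, none or still open, it means among the compounds named here.

The shared core carries an arylsulfonamide on a benzazepine bearing a methyl on the ring nitrogen. Compound 1 `Cc1noc(C)c1-c1ccc(S(=O)(=O)Nc2ccc3c(c2)CCN(C)CC3)cc1` gives 10 nM in an assay on isolated protein for displacement of a labelled ligand from 5-hydroxytryptamine receptor 6 (Homo sapiens), read by radioligand binding (a lower number here means a stronger inhibitor, a higher number a weaker inhibitor), the lowest of the two numbers recorded so far. Compound 2 `CC(C)Oc1cc2c(cc1NS(=O)(=O)c1ccc(-c3ccc(Cl)cc3)cc1)CCN(C)CC2` differs from compound 1 in more than one place. In this assay compound 2 gives 31.6 nM, a higher number that lies beyond the scatter of the method.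

Compound 3 `CCCCc1ccc(S(=O)(=O)Nc2ccc3c(c2)CCN(C)CC3)cc1` has not yet been measured. Relative to compound 1 the change is butyl in place of 3,5-dimethyl-1,2-oxazol-4-yl on an aromatic carbon. Among the compounds with values here, no single-point step between measured compounds exists in this set, so the size of the effect is not anchored by data. A moderate rise in the number, somewhat beyond the scatter, is expected for the step of a 3.0-fold higher number from compound 1 to compound 3 (0.48 log units; beyond the scatter) in this assay. Compound 3 is therefore estimated at 30 nM, with a plausible range from 8 nM to 120 nM.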

Compound 3, inhibition constant: 1.26 nM
Compound 3: the middle estimate sits 24-fold (1.38 log units) above what was measured; the whole stated range lies above it.
By their numbers in this assay, from the lowest: compound 3; then compound 1; then compound 2.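

Within the data shown here, this is the first single-place step: in this assay, replacing 3,5-dimethyl-1,2-oxazol-4-yl with butyl, para to a large group, gives a 7.9-fold lower number from compound 1 to compound 3 (0.90 log units; beyond the scatter). At this position, neither a ring nor hydrogen-bond acceptors in the substituent are needed for a low number, as the open-chain butyl has neither and still outperforms the five-membered aromatic ring. No measurement on hand accounts for the step.

This one step cannot separate the loss of the ring from the loss of the acceptors or the change in group size; a phenyl group or a methoxyethyl chain at the same carbon would begin to pull these apart. On these data alone, how far the trend extends also remains open, and a propyl, a hexyl or a tert-butyl group would test its dependence on chain length and branching.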